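The compounds below may be only part of what the source reports. "The series", "measured", "known", "first", "only" and "open" are said of these compounds alone.

Values in a functional assay on A549 cells (Homo sapiens) for antiproliferative activity, read by MTT assay; a lower number here means a stronger inhibitor, a higher number a weaker inhibitor:
- compound 1 `COC(=O)N1CCCc2cc(S(=O)(=O)N3CC(c4ccccc4)NC3=O)ccc21`: 1150 nM
- compound 2 `O=C1NC(c2ccccc2)CN1S(=O)(=O)c1ccc2c(c1)CCCN2C(=O)C(F)(F)F`: > 20000 nM, a limit
- compound 3 `O=C(NC1CCCCC1)N1CCCc2cc(S(=O)(=O)N3CC(c4ccccc4)NC3=O)ccc21`: not yet measured

Compound 2 has no number, only a limit (the limit of > 20000 nM in this assay, at which 1 of the 2 values shown sits). Going on to compound 3, cyclohexylamino comes in place of trifluoromethyl on a carbonyl carbon: cyclohexylamino in place of trifluoromethyl on a carbonyl carbon. Going by the values given here, one measured step bears on this same carbonyl carbon: an at least 17-fold higher number from compound 1 to compound 2 (1.24 log units; beyond the scatter), large and beyond the scatter. Its size is itself bounded by the limit, and cyclohexylamino has not been measured on the shared core, so that step gives direction better than size. Compound 1 at 1150 nM carries no trifluoromethyl, and on that basis a move to a lower number is expected in this assay. The expected change is an at least 5.7-fold lower number from compound 2 to compound 3 (0.75 log units; beyond the scatter), moderate to large. For compound 3 the estimated value is 3500 nM, with an expected range of 700 nM to 18000 nM.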

Compound 3, half-maximal inhibitory concentration: 231 nM
Compound 3: middle estimate off by 15-fold (1.18 log units), on the high side, outside the stated range (below it).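

In this assay, cyclohexylamino on this carbonyl carbon gives a 5.0-fold lower number from compound 1 to compound 3 (0.70 log units; beyond the scatter), so a carbon-only six-membered ring carried through an amino link is accepted at this place, and methoxy is not the best group shown here. Against trifluoromethyl, the change is an at least 86-fold lower number from compound 2 to compound 3 (1.93 log units; beyond the scatter), which makes the choice of group on this carbonyl carbon a strong handle on the number in this assay, although the true size of this step stays bounded. Compound 2 is held at a limit of the assay: the limit of > 20000 nM in this assay, at which 1 of the 3 values shown sits.

The compounds shown leave open whether the ring or the amide hydrogen of cyclohexylcarbamoyl accounts for the step from methoxy. Cyclohexyl set directly on the carbonyl carbon, or a plain methylamino group, would separate these two parts of the change.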